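Phenoxy to isopropoxy at the ether oxygen of the alkyne series

The compounds below may be only part of what the source reports. "The series", "measured", "known", "first", "only" and "open" are said of these compounds alone.

Measured so far:
compound 1 `O=C(c1ccc(C#Cc2ccc(Oc3ccccc3)cc2)cc1)N1CCC[C@@H](CO)C1` — > 10000 nM
compound 2 `COc1ccc(C#Cc2ccc(C(=O)N3CCC[C@@H](CO)C3)cc2)c(F)c1F` — > 10000 nM
compound 3 `COc1ccc(C#Cc2ccc(C(=O)N3CCC[C@@H](O)C3)c(F)c2)cc1` — 450 nM; 593 nM; 603 nM (3 entries)

In a functional assay on TREX cells for negative allosteric modulation of metabotropic glutamate receptor 3 (Rattus norvegicus), read by calcium flux, with a stated time of 2.5 min (on this read-out lower numbers stand for stronger inhibition and higher numbers for weaker inhibition), compound 1 gives only a limit, > 10000 nM; no number stands for it. Compound 2 likewise gives only a limit, > 10000 nM. Going by the values given here, compound 3 is the one compound of the three with a number, and its repeats agree with each other (the several entries of compound 3 in this assay, 450 nM; 593 nM; 603 nM (3 entries)). Two of the three entries sit at the limit (the limit of > 10000 nM in this assay, at which 2 of the 3 values shown sit), so compound 1 stands with compound 2 at the weak end of what has been seen, while compound 3 stands apart from both. Compound 3 differs from compound 1 in more than one place, so its number cannot be carried over directly.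

The step to compound 4 `CC(C)Oc1ccc(C#Cc2ccc(C(=O)N3CCC[C@@H](CO)C3)cc2)cc1` is a single change: isopropyl in place of phenyl on an oxygen on an aromatic ring. The rest of the shared core, including the hydroxymethyl piperidine amide, is kept as in compound 1. Among the compounds with values here, no measured pair shows this change, so its size is open. Given that compound 1 sits at the limit, > 10000 nM, compound 4 is expected to stay weak, with the step of an at least 1.2-fold lower number from compound 1 to compound 4 (0.09 log units; that floor lies within the scatter) taken as modest at most and quite possibly a limit again. The estimate for compound 4 is 8000 nM, within 2000 nM to 30000 nM.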

Compound 4, half-maximal inhibitory concentration: > 10000 nM
Compound 4: only a limit was reported (the forecaster's own chance of this, stated with the estimate: 55%); middle value at least 1.2-fold (0.09 log units) from the limit.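

In this assay compound 4 gives only a limit, > 10000 nM. Compound 1 likewise gives only a limit, > 10000 nM, so the step between compound 1 and compound 4 cannot be read. The compounds shown leave open whether isopropyl in place of phenyl on this oxygen changes inhibition at all, and in which direction.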